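Chloro substitution steps in a small antiproliferative series

This account rests on a few compounds, and the source may have more. Where it says the series, first, only, none or still open, it means among the compounds named here.

Compound 1 `O=C(NOCc1ccccc1F)c1cn(-c2ccccc2)nc1-c1ccccc1` gives 5940 nM in a functional assay on A549 cells (Homo sapiens) for antiproliferative activity, read by MTT assay, with a stated time of 48 h, in the presence of a further agent that is not named here; on this read-out higher numbers stand for weaker inhibition of growth and lower numbers for stronger inhibition of growth. Compound 2 `O=C(NOCc1ccccc1F)c1cn(-c2ccccc2)nc1-c1ccc(Cl)cc1` carries the change chloro in place of hydrogen on an aromatic carbon and gives 12100 nM in this assay, a step of a 2.0-fold higher number from compound 1 to compound 2 (0.31 log units; beyond the scatter). Compound 3 `O=C(NOCc1ccccc1Cl)c1cn(-c2ccccc2)nc1-c1ccc(Cl)cc1` gives 15500 nM in this assay, with a 1.3-fold higher number from compound 2 to compound 3 (0.11 log units; within the scatter). The difference between the cores of compound 3 and compound 1 is not broken down here.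

Compound 4 `O=C(NOCc1ccc(Cl)cc1Cl)c1cn(-c2ccccc2)nc1-c1ccc(Cl)cc1` is not yet measured. It differs from compound 3 by chloro in place of hydrogen on an aromatic carbon. This is the same kind of change as that from compound 1 to compound 2, not the same: in compound 4 the entering chloro is meta to a chloro group and para to a large group, whereas in compound 2 it is only para to a large group.

Among the compounds with values here, the expectation rests on the one measured instance of this change, because a 2.0-fold higher number from compound 1 to compound 2 (0.31 log units; beyond the scatter) was modest and beyond the scatter. For compound 4 in this assay a step of about a 1.6-fold higher number from compound 3 to compound 4 (0.21 log units; within the scatter) is expected. Compound 4 is estimated at 25000 nM, with a range from 12000 nM to 50000 nM.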

Compound 4, concentration for 50% growth inhibition: 13100 nM
Compound 4: middle estimate off by 1.9-fold (0.28 log units), on the high side; low and high end bracket the measured number.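

Going from 2-chlorobenzyl to 2,4-dichlorobenzyl in this assay gives a 1.2-fold lower number from compound 3 to compound 4 (0.07 log units; within the scatter), and the exchange of 2-fluorophenyl for 2,4-dichlorophenyl on the saturated chain carbon also stays within the scatter, at a 1.1-fold higher number from compound 2 to compound 4 (0.03 log units; within the scatter). The two instances of chloro in place of hydrogen on an aromatic carbon cannot be told apart on these numbers: the same change on two cores in this assay, a 2.0-fold higher number (0.31 log units; beyond the scatter) from compound 1 to compound 2 and a 1.2-fold lower number (0.07 log units; within the scatter) from compound 3 to compound 4, 2.4-fold (0.38 log units) apart, within the scatter of two such steps. Within the data shown here, this gives no evidence that the core or the surroundings of the entering chloro alter the step, but it does not show that the step carries over unchanged, since there is only one instance on each core and only one of the two steps lies beyond the scatter.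

The compounds shown leave open whether a methoxy group, an amine or a carboxylic acid, placed para to a large group where this chloro enters, would shift the number beyond the scatter. Also open, from the compounds shown here alone, is how chloro in place of hydrogen behaves on any core other than these two.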